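Cytotoxicity notes: methoxy step from compound 3 to compound 4

The compounds below may be only part of what the source reports. "The series", "measured", "known", "first", "only" and "open" are said of these compounds alone.

Measured compounds:
compound 1 `COc1ccc(C(=O)/C=C/c2ccc(OC)c(OC)c2OC)c(O)c1`: 96.6%
compound 2 `COc1ccc(CCCc2cccc(O)c2)c(OC)c1`: 97%
compound 3 `COc1ccc(C(=O)CCc2cccc(OC)c2OC)c(O)c1`: 95.2%

All three were read in an ADME assay on RAW264.7 cells (Mus musculus) for cytotoxicity, read by MTT assay, with a stated time of 24 h, tested at 2.5 ug/mL; on this read-out lower numbers stand for a stronger effect and higher numbers for a weaker effect at the one concentration tested. The number for compound 3 is the lowest of the three, yet its gap to compound 1 and its gap to compound 2 both lie within the scatter, so the three compounds cannot be told apart on this read-out. Compound 4 `COc1ccc(C(=O)CCc2ccc(OC)c(OC)c2OC)c(O)c1` has not been measured. Relative to compound 3 the change is methoxy in place of hydrogen on an aromatic carbon. Within the data shown here, no step between measured compounds is available; the expectation rests on the near-identical numbers of the three. For compound 4 the expected step of a number 0.8 percentage points higher from compound 3 to compound 4 (within the scatter) is not expected to reach beyond the scatter. Compound 4 is estimated at 96%, with a range from 90% to 100%.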

Compound 4, a percentage reported as activity, at one concentration (the size of the read-out at that concentration, not a potency): 94.4%
Beside the measured number, compound 4's estimate is 1.6 percentage points above it; the measured number falls inside the stated range.
By their numbers in this assay, from the lowest: compounds 4, 3, 1 and 2 (each within the scatter of the next).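

In this assay, among these compounds, methoxy in place of hydrogen on an aromatic carbon gives a number 0.8 percentage points lower from compound 3 to compound 4 (within the scatter) and this is the first step that changes one place only. At this position, ortho to a methoxy group, meta to a methoxy group and para to a large group, the two compounds cannot be told apart on this read-out. Among the compounds shown here, no evidence on this step is at hand. As far as these compounds go, whether an amine, a carboxylic acid or a longer chain such as ethoxy at this position would reach beyond the scatter stays open. Also open, from the compounds shown here alone, is how this pair would compare at any other concentration.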